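Swapping the halogenated ring on the saturated ring carbon

The compounds below may be only part of what the source reports. "The series", "measured", "known", "first", "only" and "open" are said of these compounds alone.

Of the compounds shown here, two of a shared core have been measured so far in an assay on cells for inhibition of histone deacetylase 4 (Homo sapiens), read by fluorescence, with a stated time of 30 min; a higher number here means a weaker inhibitor, a lower number a stronger inhibitor. Compound 1 `O=C1NC(=O)/C(=C\c2ccc(OCC(=O)N3N=C(c4ccccc4)CC3c3ccc(Cl)c(Cl)c3)cc2)S1` gives 700 nM. Compound 2 `O=C1NC(=O)/C(=C\c2ccc(OCC(=O)N3N=C(c4ccc(F)cc4)CC3c3ccc(F)cc3F)cc2)S1` gives 1600 nM, which is the higher of the two numbers, and the gap between compound 1 and compound 2 is beyond the usual scatter of this assay. Compound 3 `O=C1NC(=O)/C(=C\c2ccc(OCC(=O)N3N=C(c4ccc(F)cc4)CC3c3ccc(Cl)c(Cl)c3)cc2)S1` is not yet measured. It differs from compound 2 in one place: 3,4-dichlorophenyl in place of 2,4-difluorophenyl on a saturated ring carbon. Compound 3 is expected to move toward a lower number, a step of a 2.0-fold lower number from compound 2 to compound 3 (0.30 log units; within the scatter), because compound 1 gives 700 nM with the same 3,4-dichlorophenyl group in that place. On this basis compound 3 is estimated at 800 nM in this assay, with a range from 350 nM to 1800 nM.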

Compound 3, half-maximal inhibitory concentration: 800 nM
Compound 3: the middle estimate sits on the measured number at the digits printed; low and high end bracket the measured number.
By their numbers in this assay, from the lowest: compounds 1, 3 and 2 (each within the scatter of the next, the first and the last beyond it).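

In this assay, placing 3,4-dichlorophenyl instead of 2,4-difluorophenyl on the saturated ring carbon, with the 4-fluorophenyl group held fixed, gives a 2.0-fold lower number from compound 2 to compound 3 (0.30 log units; within the scatter), so this change alone does not separate the two compounds. Fluoro in place of hydrogen on an aromatic carbon, with the 3,4-dichlorophenyl group held fixed, gives a 1.1-fold higher number from compound 1 to compound 3 (0.06 log units; within the scatter), so neither single change lies beyond the scatter. No measurement available here gives a reason for either step.

The swap on the saturated ring carbon alters the kind of halogen and its place on the ring together, so these compounds cannot tell the two apart. Only halogenated phenyl groups stand at that carbon here, which leaves open how a phenyl ring carrying a methoxy group or an amine would read there.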